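This account rests on a few compounds, and the source may have more. Where it says the series, first, only, none or still open, it means among the compounds named here.

Compound 1 `O=C(/C=C/c1ccc(COc2ccccc2)cc1)NO`: 8400 nM
Compound 2 `Nc1ccccc1NC(=O)c1ccc(COc2ccc(Br)cc2)cc1`: > 32000 nM, a limit of the assay rather than a number
Compound 3 `Nc1ccccc1NC(=O)c1ccc(CN2CCc3cc(Br)ccc32)cc1`: 10700 nM

All three values come from a functional assay on HepG2 cells (Homo sapiens) for antiproliferative activity, read by CCK-8 assay, with a stated time of 72 h; on this read-out lower numbers stand for stronger inhibition and higher numbers for weaker inhibition. Compound 1 gives 8400 nM and compound 3 gives 10700 nM. For compound 2 this assay returns only a limit, > 32000 nM, so no number is known for it; this is the limit of > 32000 nM in this assay, at which 1 of the 3 values shown sits. Among the three compounds, compound 2 therefore stands at the weak end of what was measured, and no step between any two of them differs in a single place, so the values of compound 1 and compound 3 say nothing direct about the change now in question.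

Compound 4 `CCc1ccc(OCc2ccc(C(=O)Nc3ccccc3N)cc2)cc1` differs from compound 2 in one place: ethyl in place of bromo on an aromatic carbon. No measured pair shows what such a change does in this assay, so the direction of the step cannot be read from the numbers shown; the step is expected to be modest, not clearly beyond the scatter. Compound 4 is expected to give about 25000 nM, in a range from 8000 nM to 80000 nM, which means an expected step of an at least 1.2-fold lower number from compound 2 to compound 4 (0.10 log units; that floor lies within the scatter).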

Compound 4, half-maximal inhibitory concentration: 6960 nM
Compound 4: middle estimate off by 3.6-fold (0.56 log units), on the high side; the whole stated range lies above it.
By their numbers in this assay, from the lowest: compounds 4, 1 and 3 (each within the scatter of the next). At a limit, above all of these: compound 2.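

In this assay, for the compounds shown here, the change from 4-bromophenyl to 4-ethylphenyl gives the first reading at this position, on an aromatic carbon para to a large group, and the step is an at least 4.5-fold lower number from compound 2 to compound 4 (0.66 log units; beyond the scatter). The earlier compounds shown here offered no pair that differed in one place, whereas this pair shows that the group on this carbon alone can move the read-out beyond the scatter, even though the exchange replaces 1 heavy atom with 2 and neither group carries a hydrogen-bond donor, a hydrogen-bond acceptor or a net charge. The true size of the step remains unknown, and the printed figure is only a floor because compound 2 stands at a limit: the limit of > 32000 nM in this assay, at which 1 of the 4 values shown sits.

The compounds shown do not tell whether the lower number belongs to ethyl in particular or would also come with another group at this carbon, such as methyl, a longer chain like propyl, methoxy or an amine. On these data alone, it also remains open whether ethyl in place of bromo would act the same way on the core of compound 3, which carries bromo on a different core.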